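The source may hold more compounds than are shown below. What is called first, only, known or untested is meant among the compounds shown, and "the series" means these compounds.

Measured so far in an in vitro functional assay on 1321-N1 cells for agonist activity at P2Y purinoceptor 2 (Homo sapiens), read by scintillation proximity assay and inositol phosphate accumulation; a higher number here means that more compound is needed for the effect, a lower number that less compound is needed:
compound 1 `O=c1ccn([C@@H]2O[C@H](COP(=O)(O)O)[C@@H](O)[C@H]2O)c(SCCc2ccccc2)n1`, 1300 nM
compound 2 `COc1nc(=O)ccn1[C@@H]1O[C@H](COP(=O)(O)OP(=O)(O)O)[C@@H](O)[C@H]1O`, 907 nM

Compound 2 and compound 1 lie within the scatter of each other in this assay, so neither stands apart. Compound 3 `O=c1ccn([C@@H]2O[C@H](COP(=O)(O)OP(=O)(O)O)[C@@H](O)[C@H]2O)c(SCCc2ccccc2)n1` is not yet measured. It differs from compound 2 by phenethylsulfanyl in place of methoxy on an aromatic carbon; compound 1 already carries the phenethylsulfanyl group. Among the compounds with values here, no step between measured compounds has been determined for this change. None beyond the scatter is expected in either direction, since compound 1 with 1300 nM and compound 2 with 907 nM sit close together. Compound 3 is expected at 700 nM, range 250 nM to 2000 nM. The expected step is a 1.3-fold lower number from compound 2 to compound 3 (0.11 log units; within the scatter).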

Compound 3, half-maximal effective concentration: 544 nM
The estimate for compound 3 lay 1.3-fold (0.11 log units) above the measured number; the range from low to high includes it.
By their numbers in this assay, from the lowest: compounds 3, 2 and 1 (each within the scatter of the next, the first and the last beyond it).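

In this assay, phenethylsulfanyl and methoxy are not told apart on the aromatic carbon between two ring nitrogen atoms: a 1.7-fold lower number from compound 2 to compound 3 (0.22 log units; within the scatter). With phenethylsulfanyl held in place, a group of 4 heavy atoms in place of a hydrogen atom on an oxygen gives a modest step, a 2.4-fold lower number from compound 1 to compound 3 (0.38 log units; beyond the scatter), the only one in the series beyond the scatter. Nothing available accounts for either step.

Open, on these data alone, is whether an amine or a methylsulfanyl group at this position would read the same. Also open, as far as these compounds go, is whether the phenyl ring or the two-carbon chain of phenethylsulfanyl contributes at all.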